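Cytotoxicity on HT-29 cells: a change of the aryl group

This account rests on a few compounds, and the source may have more. Where it says the series, first, only, none or still open, it means among the compounds named here.

Measured compounds:
- Compound 1 `Cc1ccc(C2=Nn3c(Cc4ccc(S(C)(=O)=O)cc4)nnc3SC2)cc1`: 1.26%
- Compound 2 `CS(=O)(=O)c1ccc(Cc2nnc3n2N=C(c2cc4ccccc4c(=O)o2)CS3)cc1`: 25.6%
- Compound 3 `CS(=O)(=O)c1ccc(Cc2nnc3n2N=C(c2ccc(-c4ccccc4)cc2)CS3)cc1`: 60.2%

Of the compounds shown here, three sharing one core have been read in a functional assay on HT-29 cells (Homo sapiens) for cytotoxicity, read by MTT assay, with a stated time of 48 h, tested at 25 uM; on this read-out higher numbers stand for a stronger effect at the one concentration tested and lower numbers for a weaker effect. Compound 1 stands lowest of the three; in this assay compound 1 gives 1.26%, while compound 2 gives 25.6% and compound 3 gives 60.2%, both beyond the scatter above compound 1.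

Compound 4 `CS(=O)(=O)c1ccc(Cc2nnc3n2N=C(c2ccc(O)c(C(N)=O)c2)CS3)cc1` has not yet been measured. It differs from compound 1 in one place: 3-carbamoyl-4-hydroxyphenyl in place of 4-methylphenyl on a carbon with a double bond to nitrogen. Going by the values given here, no measured step swaps the aryl group in this way. Among the compounds with values here, the only step recorded, a number 58.9 percentage points higher from compound 1 to compound 3 (beyond the scatter), replaces a methyl with a phenyl and was large; compound 2, which carries a fused bicyclic aryl group in the same place, also sits well above compound 1. Both therefore show that changing this aryl group can move the read-out strongly upwards from the low value of compound 1, but neither resembles the carbamoyl and hydroxy substitution of compound 4.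

The estimate for compound 4 in this assay is 15% (range 0% to 45%). This corresponds to an expected step of a number 13.7 percentage points higher from compound 1 to compound 4 (beyond the scatter), a modest rise that may or may not clear the scatter.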

Compound 4, a percentage reported as activity, at one concentration (the size of the read-out at that concentration, not a potency): 24.7%
Compound 4: middle estimate off by 9.7 percentage points, on the low side; measured number inside the range.
By their numbers in this assay, from the lowest: compound 1; then compounds 4 and 2 (each within the scatter of the next); then compound 3.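

In this assay, 3-carbamoyl-4-hydroxyphenyl in place of 4-methylphenyl gives a number 23.4 percentage points higher from compound 1 to compound 4 (beyond the scatter), and it does so with one six-membered aromatic ring of carbon only, the same ring count as the group it replaces. The two earlier rises came with aryl groups holding a second ring, so compound 4 shows that substituents on a single ring at this carbon can also lift the read-out clear of compound 1, here with added nitrogen and oxygen atoms and hydrogen-bond donors and acceptors. Compound 4 and compound 2 lie within the scatter of each other, while compound 3 gives 60.2% and so remains the one clear high point of the set; no measurement at hand accounts for any of these differences.

The compounds shown leave open whether the carbamoyl group or the hydroxy group alone would give a similar number on this ring. They also leave open how an amine or a carboxylic acid on the same aryl ring would read in this assay and whether such a group could approach compound 3.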